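The source may hold more compounds than are shown below. What is called first, only, known or untested is meant among the compounds shown, and "the series" means these compounds.

Compound 1 `CC1=CC[C@@H]([C@@](C)(O)CCCC(C)(C)NC=S)CC1`: 11000 nM
Compound 2 `CC1=CC[C@@H]([C@@](C)(O)CCCC(C)(C)NC(=S)N/N=C\c2ccc(O)cc2)CC1`: 6230 nM

In a functional assay on PCO3 cells (Homo sapiens) for cytotoxicity, read by sulforhodamine B assay (on this read-out lower numbers stand for stronger inhibition of growth and higher numbers for weaker inhibition of growth), compound 1 gives 11000 nM and compound 2 gives 6230 nM. Compound 2 has the lower of the two numbers, but the gap to compound 1 lies within the scatter, so the two stand level on these values. Compound 3 `CC1=CC[C@@H]([C@@](C)(O)CCCC(C)(C)NC(=S)N/N=C\c2ccccc2Cl)CC1` differs from compound 2 by 2-chlorophenyl in place of 4-hydroxyphenyl on a carbon with a double bond to nitrogen. For the measured compounds named here, no comparable step between measured compounds exists, so the size of the step is uncertain. A small step toward a lower number, if any beyond the scatter, is expected from compound 2 to compound 3, a 1.2-fold lower number from compound 2 to compound 3 (0.10 log units; within the scatter). Compound 3 is estimated at 5000 nM, within 2000 nM to 12500 nM.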

Compound 3, concentration for 50% growth inhibition: 18800 nM
The estimate for compound 3 lay 3.8-fold (0.58 log units) below the measured number; the whole stated range lies below it.
By their numbers in this assay, from the lowest: compounds 2, 1 and 3 (each within the scatter of the next, the first and the last beyond it).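

In this assay, for the compounds shown here, the group on a carbon with a double bond to nitrogen is not indifferent: 2-chlorophenyl in place of 4-hydroxyphenyl brings a 3.0-fold higher number from compound 2 to compound 3 (0.48 log units; beyond the scatter) and so moves growth inhibition toward the weaker side, a change at this position that the earlier compounds did not show. Nothing available explains this step. The compounds shown leave open whether the step follows the loss of the hydroxyl or the arrival of the chlorine, as both change together. Going by these compounds, how a plain phenyl or a methoxy-bearing phenyl would stand at this position also remains open.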